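The source may report more compounds than this note shows. Statements on the series, on what has been measured and on what is new or still open speak of the compounds shown alone.

Values in a functional assay on COLO 205 cells (Homo sapiens) for antiproliferative activity; on this read-out lower numbers stand for stronger inhibition of growth and higher numbers for weaker inhibition of growth:

- compound 1 `COCCCCCCCCCCCCCCC/C=C1\CC(CO)(COC(=O)C(C)(C)C)OC1=O` gives 0.118 ug/mL
- compound 2 `CC(C)(C)C(=O)OCC1(CO)C/C(=C\CCCCCCCCCCCCCCC=O)C(=O)O1` gives > 10 ug/mL (a limit of the assay)
- compound 3 `CC(=O)OCCCCCCCCCCCCCCC/C=C1\CC(CO)(COC(=O)C(C)(C)C)OC1=O` gives 2.1 ug/mL

Compound 3 holds the higher of the two actual numbers, with an 18-fold higher number from compound 1 to compound 3 (1.25 log units; beyond the scatter). Compound 2 gives only a limit, so it cannot be ranked exactly.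

The next analogue is compound 4 `CC(C)(C)C(=O)OCCCCCCCCCCCCCCC/C=C1\CC(CO)(COC(=O)C(C)(C)C)OC1=O`, which differs from compound 3 by tert-butyl in place of methyl on a carbonyl carbon, or acetoxy to ((tert-butyl)carbonyl)oxy.

The chain end clearly matters in this assay, as shown by an 18-fold higher number from compound 1 to compound 3 (1.25 log units; beyond the scatter) and by an at least 4.7-fold lower number from compound 2 to compound 3 (0.67 log units; beyond the scatter). Neither step swaps one acyl group for another, so neither sizes this change directly. Compound 3 and compound 4 both keep a carbonyl on the terminal oxygen, so a much smaller change is expected than the large step to compound 3 from compound 1. The expected result is a 1.2-fold higher number from compound 3 to compound 4 (0.08 log units; within the scatter), with no clear direction beyond the scatter. The estimate for compound 4 is 2.5 ug/mL, with an expected range of 0.7 ug/mL to 9 ug/mL.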

Compound 4, concentration for 50% growth inhibition: 0.597 ug/mL
The estimate for compound 4 lay 4.2-fold (0.62 log units) above the measured number, outside the stated range (below it).
By their numbers in this assay, from the lowest: compound 1; then compound 4; then compound 3. At a limit, above all of these: compound 2.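

In this assay the acyl group on the terminal oxygen is not a neutral carrier: with tert-butyl in place of methyl on a carbonyl carbon there is a 3.5-fold lower number from compound 3 to compound 4 (0.55 log units; beyond the scatter), yet with (tert-butyl)carbonyl in place of the terminal methyl there is still a 5.1-fold higher number from compound 1 to compound 4 (0.70 log units; beyond the scatter), so this acyl end recovers only part of the gap to the methyl ether. The formyl end gives only a limit of the assay, so this step is a bound and not an exact size: an at least 16-fold lower number from compound 2 to compound 4 (1.22 log units; beyond the scatter), in favour of the acyl end. No measured property accounts for the change at this position.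

Two acyl groups cannot show whether the number falls steadily with the carbons of the acyl group. Going by these compounds, how a benzoyl group, a free hydroxyl or an amine at the chain end would compare with the methyl ether stays open.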